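The source may report more compounds than this note shows. Statements on the series, on what has been measured and on what is new or still open speak of the compounds shown alone.

Among the measured compounds shown here, in a functional assay on Jurkat cells (Homo sapiens) (on this read-out lower numbers stand for stronger inhibition and higher numbers for weaker inhibition), compound 2 `CC(C)[C@H](NC(=O)COc1cccc2ccccc12)C(=O)N[C@@H](CC(=O)O)C(=O)COc1cc(F)cc(F)c1F` gives 30000 nM, the only true number available so far. Compound 1 `CC(C)[C@H](NC(=O)COc1cccc2ccccc12)C(=O)N[C@@H](CC(=O)O)C(=O)COc1ccc2ccccc2c1` shows > 100000 nM, which is a limit of the assay and not a number. For the measured compounds named here, compound 2 therefore stands on the stronger side of the only comparison that can be made, though a single pair says little about how good or poor its value is in general.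

The next structure is compound 3 `CC(C)[C@H](NC(=O)COc1cccc2ccccc12)C(=O)N[C@@H](CC(=O)O)C(=O)COc1c(F)c(F)c(F)c(F)c1F`, which has 2,3,4,5,6-pentafluorophenyl in place of 2,3,5-trifluorophenyl on an oxygen on a saturated carbon. The rest of the molecule stays the same.

Going by the values given here, only one measured step bears on this change: an at least 3.3-fold lower number from compound 1 to compound 2 (0.52 log units; beyond the scatter). That step lies beyond the scatter, but it replaced naphthalen-2-yl with a fluorinated phenyl group, whereas this change swaps one fluorinated phenyl group for another. Among the compounds with values here, no measured pair compares two such groups, so the earlier step offers only a loose guide. A small move towards a lower number is expected, perhaps none beyond the scatter.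

The estimated step is a 1.5-fold lower number from compound 2 to compound 3 (0.18 log units; within the scatter). For compound 3, the expected value is 20000 nM, with an estimated range from 5000 nM to 80000 nM.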

Compound 3, half-maximal inhibitory concentration: 3050 nM
Compound 3: the middle estimate sits 6.6-fold (0.82 log units) above what was measured, outside the stated range (below it).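

In this assay, going from 2,3,5-trifluorophenyl to 2,3,4,5,6-pentafluorophenyl on the oxygen gives a 9.8-fold lower number from compound 2 to compound 3 (0.99 log units; beyond the scatter), so the read-out at this position responds to a change among fluorinated phenyl groups and not only to the departure of naphthalen-2-yl. Compound 1 carries a limit of the assay and not a number: the limit of > 100000 nM in this assay, at which 1 of the 3 values shown sits. Replacing naphthalen-2-yl with 2,3,4,5,6-pentafluorophenyl gives an at least 32-fold lower number from compound 1 to compound 3 (1.51 log units; beyond the scatter), which shows that this one group can shift the read-out widely while the rest of the molecule stays the same.

As far as these compounds go, with only these two fluorinated rings, it remains open whether the stronger inhibition follows the number of fluorine atoms or the particular places they occupy, and a 2,3,5,6-tetrafluorophenyl group or a pentachlorophenyl group would help to separate these readings. From the compounds shown here alone, it is also open how this read-out would respond to a plain phenyl group on the same oxygen, or to a methyl ester in place of the carboxylic acid of the shared core.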